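Oxan-4-yl for 3-methoxyphenyl in compound 1

The compounds below may be only part of what the source reports. "The series", "measured", "known", "first", "only" and "open" are said of these compounds alone.

In a physicochemical assay for solubility (on this read-out higher numbers stand for higher solubility and lower numbers for lower solubility), compound 1 (`CNC(=O)c1cc(C(=O)N[C@H]2[C@@H]3COC[C@@H]32)cc2c1OC[C@H]2c1cccc(OC)c1`) gives >= 186 ug/mL, which is a limit and not a number. Compound 2 (`CNC(=O)c1cc(C(=O)NC2CC2)cc2c1OC[C@H]2c1cccc(OC)c1`) gives >= 161 ug/mL, also a limit. Compound 3 (`CNC(=O)c1cc(C(=O)N[C@H]2CC[C@H](O)CC2)cc2c1OC[C@@]2(C)c1ccccc1`) gives >= 161 ug/mL, again a limit. Compound 4 (`CNC(=O)c1cc(C(=O)N[C@H]2[C@@H]3COC[C@@H]32)cc2c1OC[C@H]2C1CCOCC1`) carries oxan-4-yl in place of 3-methoxyphenyl on a saturated ring carbon. For the measured compounds named here, the only measured step, a step that the two limits leave unreadable from compound 1 to compound 2, lies on an amide-type nitrogen, so it does not bear directly on this change and gives no size to carry over. No step beyond the scatter is therefore expected in this assay, and no direction is predicted. The expected change is an at least 1.0-fold lower number from compound 1 to compound 4 (0.02 log units; that floor lies within the scatter). For compound 4 the estimate is 176 ug/mL, with an expected range of 110 ug/mL to 200 ug/mL.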

Compound 4, solubility: >= 177 ug/mL
Compound 4 gave a limit, no number (the forecaster's own chance of this, stated with the estimate: 75%); middle value at least 1.0-fold (0.00 log units) from the limit.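

Compound 1 and compound 4 both return limits, not numbers, in this assay, so the step between them cannot be read. The compounds shown leave open whether oxan-4-yl and 3-methoxyphenyl differ at all on this read-out.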